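Compound 3 Gives Up Its Aromatic Ring

This account rests on a few compounds, and the source may have more. Where it says the series, first, only, none or still open, it means among the compounds named here.

In a physicochemical assay for lipophilicity, at pH 7.4 (a higher number here means a more lipophilic compound, a lower number a more polar compound), compound 3 `CNC(=O)c1cc(C(=O)NC2CC2)cn(Cc2cccc(C)c2)c1=O` stands highest of the three measured compounds at 3.6, ahead of compound 1 `CNC(=O)c1cc(C(=O)NC2CC2)cn(Cc2ccc(F)cc2)c1=O` at 3.2 and compound 2 `CNC(=O)c1cc(C(=O)NC2CC2)cn(Cc2cccc3[nH]ccc23)c1=O` at 2.9. Compound 4 `CNC(=O)c1cc(C(=O)NC2CC2)cn(CC2CCCOC2)c1=O` differs from compound 3 as follows: oxan-3-yl in place of 3-methylphenyl on a saturated chain carbon bound to an aromatic nitrogen. In words, oxan-3-yl stands in place of 3-methylphenyl on a saturated chain carbon bound to an aromatic nitrogen. The closest guides are a number 0.40 log units higher from compound 1 to compound 3 (beyond the scatter) and a number 0.70 log units higher from compound 2 to compound 3 (beyond the scatter), both modest, but each only exchanges one aromatic group for another. For the measured compounds named here, no measured step removes the aromatic ring. A downward move larger than either is therefore expected. The estimated step is a number 1.40 log units lower from compound 3 to compound 4 (beyond the scatter). Compound 4 is expected at 2.2, with an estimated range from 1.7 to 2.7.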

Compound 4, distribution coefficient: 2
Compound 4: middle estimate off by 0.20 log units, on the high side; the measured number falls inside the stated range.
By their numbers in this assay, from the lowest: compound 4; then compounds 2 and 1 (each within the scatter of the next); then compound 3.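

Compound 4 is the first compound shown with a non-aromatic ring at this position, and in this assay it lies lower than each compound bearing an aromatic group (a number 1.60 log units lower from compound 3 to compound 4 (beyond the scatter); a number 1.20 log units lower from compound 1 to compound 4 (beyond the scatter); a number 0.90 log units lower from compound 2 to compound 4 (beyond the scatter)). All three steps lie beyond the scatter, and the position on a saturated chain carbon bound to an aromatic nitrogen now spans a wider range than the aromatic groups alone showed. Nothing measured here accounts for the size of these steps.

As far as these compounds go, it remains open how the fall divides between losing the aromatic ring and gaining the ring oxygen, which a cyclohexyl group at this place would help separate. From the compounds shown here alone, how a piperidinyl ring, which carries an amine, would read also remains open.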